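The source may hold more compounds than are shown below. What is called first, only, known or untested is meant among the compounds shown, and "the series" means these compounds.

For the measured compounds named here, in a toxicity assay on HaCaT cells (Homo sapiens) for cytotoxicity, read by MTT assay (on this read-out higher numbers stand for weaker inhibition and lower numbers for stronger inhibition), compound 2 `Oc1cc(C(F)(F)F)ccc1-c1nc(-c2ccccc2O)n(-c2ccc(Br)cc2)n1` gives 29600 nM, the lowest of three numbers so far, against compound 1 `Cc1ccc(-n2nc(-c3ccc(C(F)(F)F)cc3O)nc2-c2ccccc2O)cc1` at 81800 nM and compound 3 `COc1cccc(-n2nc(-c3ccc(C(F)(F)F)cc3O)nc2-c2ccccc2O)c1` at 81100 nM. Compound 4 `Cc1ccc(-n2nc(-c3ccc(C(F)(F)F)cc3O)nc2-c2ccccc2O)c(C)c1` has 2,4-dimethylphenyl in place of 4-bromophenyl on an aromatic nitrogen. The closest evidence is bromo in place of methyl, which gave a 2.8-fold lower number from compound 1 to compound 2 (0.44 log units; beyond the scatter), a modest step. Leaving the 4-bromophenyl for 3-methoxyphenyl gave a similar modest rise, a 2.7-fold higher number from compound 2 to compound 3 (0.44 log units; beyond the scatter), while a 1.0-fold lower number from compound 1 to compound 3 (0.00 log units; within the scatter) stayed within the scatter. Going by the values given here, no measured compound shows what a second methyl adds. A modest rise is therefore expected, a 2.4-fold higher number from compound 2 to compound 4 (0.37 log units; beyond the scatter). For compound 4 the estimated value is 70000 nM, with an expected range of 35000 nM to 140000 nM.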

Compound 4, half-maximal inhibitory concentration: 94800 nM
For compound 4 the middle estimate is 1.4-fold (0.13 log units) below the measured one; the range from low to high includes it.
By their numbers in this assay, from the lowest: compound 2; then compounds 3, 1 and 4 (each within the scatter of the next).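

In this assay the added methyl shows no readable effect, with a 1.2-fold higher number from compound 1 to compound 4 (0.06 log units; within the scatter), and moving from the 3-methoxyphenyl gives a 1.2-fold higher number from compound 3 to compound 4 (0.07 log units; within the scatter). Compound 2 alone stands apart among these groups on the aromatic nitrogen, now also with a 3.2-fold higher number from compound 2 to compound 4 (0.51 log units; beyond the scatter), so three differently decorated phenyl groups sit together while the 4-bromophenyl does not. Nothing measured here gives a reason for this difference. Open, from the compounds shown here alone, is whether a 4-chlorophenyl or 4-fluorophenyl would side with compound 2 or with the other three. Going by these compounds, how a phenyl carrying an amine or a carboxylic acid would behave here also remains unknown.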